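The compounds below may be only part of what the source reports. "The series", "measured", "known", "first", "only" and "open" are said of these compounds alone.

Of the compounds shown here, three have so far been measured in a functional assay on CHO cells for antagonist activity at prostaglandin E2 receptor EP3 subtype (Homo sapiens), read by cAMP accumulation, with a stated time of 30 min; on this read-out lower numbers stand for stronger inhibition and higher numbers for weaker inhibition. Compound 1 `CCc1cccc2ccc(-c3ccc(C(/C=C4\OC(=O)NC4=O)(CC)CC)c(=O)[nH]3)cc12` gives 91 nM, compound 2 `O=C1NC(=O)/C(=C/C(c2ccc(-c3ccc4cccc(F)c4c3)[nH]c2=O)C2CCCCC2)O1` gives 8 nM, and compound 3 `CC(C)/C(=C1\C(=O)NC(=O)N1C)c1ccc(-c2ccc3cccc(F)c3c2)[nH]c1=O` gives 350 nM. Compound 2 thus carries the lowest number of the three, and its gaps to compound 1 and to compound 3 both lie beyond the usual scatter of such measurements. Compound 4 `O=C1NC(=O)/C(=C/C(Cc2ccccc2)c2ccc(-c3ccc4cccc(F)c4c3)[nH]c2=O)O1` has not yet been measured. It differs from compound 2 in one place: benzyl in place of cyclohexyl on a saturated chain carbon bound to an aromatic carbon and a double-bonded chain carbon. Going by the values given here, no measured pair shows this exchange, so its effect can only be anticipated. A somewhat higher number, meaning a weaker effect in this assay, is expected, with the step of a 3.1-fold higher number from compound 2 to compound 4 (0.49 log units; beyond the scatter). Compound 4 is therefore estimated at 25 nM, within a range from 6 nM to 100 nM.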

Compound 4, half-maximal inhibitory concentration: 200 nM
Compound 4: the middle estimate sits 8.0-fold (0.90 log units) below what was measured; the whole stated range lies below it.
By their numbers in this assay, from the lowest: compound 2; then compound 1; then compounds 4 and 3 (each within the scatter of the next).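

In this assay, the saturated chain carbon proves sensitive to what it carries: benzyl in place of cyclohexyl gives a 25-fold higher number from compound 2 to compound 4 (1.40 log units; beyond the scatter), a large weakening. Both groups hold a six-membered ring of carbon only, cyclohexyl a non-aromatic one and benzyl an aromatic one, so having such a ring at this place does not by itself keep the low number of compound 2. Nothing available explains the size of this step. Still open, from the compounds shown here alone, is whether cyclopentyl or a hexyl chain at this place would stay near compound 2 or fall nearer compound 4.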